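Permeability Ahead of a Hydroxyalkyl Step on Compound 1

The compounds below may be only part of what the source reports. "The series", "measured", "known", "first", "only" and "open" are said of these compounds alone.

Compound 1 `Nc1cc(Oc2ccc(NC(=O)Nc3cccc(C(F)(F)F)c3)cc2)ncn1` gives 245 nm/s
Compound 2 `CCc1cc(NC(=O)Nc2cccc(C(F)(F)F)c2)cc(Cl)c1Oc1cc(NC)ncn1` gives 59 nm/s
Compound 3 `CNc1cc(Oc2c(C)cc(NC(=O)Nc3cccc(C(F)(F)F)c3)cc2C)ncn1` gives 295 nm/s

These numbers come from an ADME assay for permeability, with a stated time of 2 h (a higher number here means that the compound crosses the layer faster, a lower number that the compound crosses the layer more slowly), and they are the only ones available so far. Compound 1 at 245 nm/s lies within the scatter of compound 3 at 295 nm/s and so the two cannot be told apart. Compound 2 at 59 nm/s gives a lower number than compound 1, and that gap lies beyond the scatter. Going by the values given here, no two of the measured compounds differ in just one place, so no measured step speaks directly to the next compound.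

That compound is compound 4 `CC(C)(O)CNc1cc(Oc2ccc(NC(=O)Nc3cccc(C(F)(F)F)c3)cc2)ncn1` which is still to be measured in this assay and which departs from compound 1 by one change: 2-hydroxy-2-methylpropyl in place of hydrogen on a nitrogen on an aromatic ring with 2-hydroxy-2-methylpropyl in place of hydrogen on a nitrogen on an aromatic ring. Among the compounds with values here, with no direct precedent, a downward move of moderate size is expected, though the data cannot rule out a result within the scatter. The expected change is a 2.2-fold lower number from compound 1 to compound 4 (0.35 log units; beyond the scatter) and it is only an estimate. For compound 4 the estimated number is 110 nm/s and the expected range runs from 35 nm/s to 280 nm/s for now.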

Compound 4, apparent permeability: 210 nm/s
Beside the measured number, compound 4's estimate is 1.9-fold (0.28 log units) below it; low and high end bracket the measured number.
By their numbers in this assay, from the lowest: compound 2; then compounds 4, 1 and 3 (each within the scatter of the next).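

In this assay, going by these compounds alone, the step of a 1.2-fold lower number from compound 1 to compound 4 (0.07 log units; within the scatter) is the first comparison in this set between two compounds that differ in one place, and it gives this nitrogen its first direct reading. It shows that 2-hydroxy-2-methylpropyl in place of hydrogen on a nitrogen on an aromatic ring, amino to (2-hydroxy-2-methylpropyl)amino, adds 5 heavy atoms, including a hydrogen-bond donor, and still leaves compound 4 indistinguishable from compound 1 in this read-out. No measurement of any other property bears on this result, so it stands here without an explanation.

The compounds shown leave open whether this holds for other groups on the same nitrogen, such as a longer chain, a chain ending in a carboxylic acid, or one ending in an amine rather than a hydroxyl. They also leave open whether 2-hydroxy-2-methylpropyl would behave in the same way on the more substituted cores of compound 2 and compound 3, where the same nitrogen carries methyl instead of hydrogen.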